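The source may hold more compounds than are shown below. What is called first, only, known or untested is meant among the compounds shown, and "the series" means these compounds.

Compound 2, `O=C(COc1ccc(Oc2ccccc2)cc1)Cn1ncc2cc(NC(=O)CO)ccc21`, and compound 1, `CC(=O)Nc1ccc2c(cnn2CC(=O)COc2ccc(Oc3ccccc3)cc2)c1`, share one core and differ only in a single small group. In an assay on microsomes from brain for inhibition of Fatty-acid amide hydrolase 1 (Rattus norvegicus), read by fluorescence and HPLC, with a stated time of 45 min (a higher number here means a weaker inhibitor, a lower number a stronger inhibitor), compound 1 gives 3900 nM, while compound 2 gives 5400 nM. Compound 2 thus holds the highest of the two numbers seen so far, with compound 1 nearest to it, and the step of a 1.4-fold higher number from compound 1 to compound 2 (0.14 log units; within the scatter) shows that exchanging hydrogen for hydroxy on that chain carbon left the potency essentially unchanged.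

Compound 3, `O=C(COc1ccc(Oc2ccccc2)cc1)Cn1ncc2cc(NC(=O)NC3CCCCC3)ccc21`, is the next compound, not yet measured in this assay. It differs from compound 2 as follows: cyclohexylamino in place of hydroxymethyl on a carbonyl carbon. A much larger group, carrying its own six-membered ring, replaces a very small one on the carbonyl carbon next to the amide-type nitrogen.

Within the data shown here, the only measured step, from compound 1 to compound 2, concerns a different change and was within the scatter, so it offers little direct guidance for this larger exchange. With no closer comparison available, the expectation rests on the size of the change alone. Compound 3 is estimated at 1500 nM, within a range of 300 nM to 8000 nM, which would mean an expected step of a 3.6-fold lower number from compound 2 to compound 3 (0.56 log units; beyond the scatter).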

Compound 3, half-maximal inhibitory concentration: 840 nM
Compound 3: middle estimate off by 1.8-fold (0.25 log units), on the high side; the range from low to high includes it.
By their numbers in this assay, from the lowest: compound 3; then compounds 1 and 2 (each within the scatter of the next).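

In this assay, the group on this carbonyl carbon clearly matters: the step to cyclohexylamino, a 6.4-fold lower number from compound 2 to compound 3 (0.81 log units; beyond the scatter), lies beyond the scatter, whereas the earlier exchange of hydrogen for hydroxy could not be told apart from it. Starting from methyl rather than hydroxymethyl, the same group again gives a step beyond the scatter, a 4.6-fold lower number from compound 1 to compound 3 (0.67 log units; beyond the scatter), so the stronger inhibition appears against both of the small groups shown. Nothing measured here explains why the number falls with this change.

Cyclohexylamino brings in both a six-membered ring and a nitrogen on the carbonyl carbon, so these compounds leave open which of the two matters; a plain cyclohexyl group or a small methylamino group in that place would help to separate them. Also open, as far as these compounds go, is how far the effect extends, for example whether a phenyl ring or a longer carbon chain on that nitrogen would give a lower or a higher number than cyclohexylamino.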